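The compounds below may be only part of what the source reports. "The series", "measured", "known", "first", "only" and "open" are said of these compounds alone.

Measured so far:
Compound 1, `CCCCCCCCCCc1cc2cn(COCCO)c(O)nc-2n1`, in a functional assay on HEL cells (Homo sapiens), read by microscopy (a higher number here means that more compound is tolerated, a lower number that less compound is tolerated), gives 80000 nM.
Compound 2, `CCCCc1cc2cn(COCCO)c(=O)nc2o1`, in this assay gives > 400000 nM, which is a limit of the assay and not a number.

Compound 2 thus stands at the tolerant end of what has been seen: the limit of > 400000 nM in this assay, at which 1 of the 2 values shown sits. Compound 1 carries a longer chain on a different core and gives a number inside the measured range. For the measured compounds named here, no step between the two measured compounds is available, so their values can only be set side by side.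

Compound 3, `CCCCCCCCCCCc1cc2cn(COCCO)c(=O)nc2o1`, differs from compound 2 by heptyl in place of hydrogen on a saturated chain carbon, four bonds along the chain from an aromatic carbon. The chain of compound 2 is lengthened while its core is kept. Going by the values given here, compound 1, the only measured compound with a chain of comparable length, gives 80000 nM, so a step toward a lower tolerated concentration, beyond the scatter, is expected. For compound 3 the expected step is an at least 4.0-fold lower number from compound 2 to compound 3 (0.60 log units; beyond the scatter). Compound 3 is estimated at 100000 nM, within 30000 nM to 400000 nM.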

Compound 3, minimum cytotoxic concentration: 80000 nM
For compound 3 the middle estimate is 1.3-fold (0.10 log units) above the measured one; the range from low to high includes it.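

In this assay, for the compounds shown here, heptyl in place of hydrogen on a saturated chain carbon, four bonds along the chain from an aromatic carbon, gives the only step on this core so far: an at least 5.0-fold lower number from compound 2 to compound 3 (0.69 log units; beyond the scatter). The value of compound 2, > 400000 nM, is a limit of the assay and not a number. From the compounds shown here alone, with the core kept, this position therefore responds to a lengthening of the chain, but the step is known only as a minimum and its full size stays unknown: the limit of > 400000 nM in this assay, at which 1 of the 3 values shown sits.

The compounds shown leave open whether the tolerated concentration falls steadily with chain length or drops at one particular length, and whether a longer chain would lower it further. They also leave open what an amine or a carboxylic acid in place of the chain would do here.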